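A few compounds are considered here, and "the series" means these few. Any claim that something is new, unique, unknown or untested is made for them only; others in the source may bear on it.

Measured so far in a functional assay on SK-HEP1 cells (Homo sapiens) for antiproliferative activity, read by sulforhodamine B assay, with a stated time of 72 h; a lower number here means a stronger inhibitor, a higher number a weaker inhibitor:
- compound 1 `CCOC(=O)c1cnc2ccc(-c3cnc(OC)c(NS(=O)(=O)c4ccc(F)cc4F)c3)cn12` gives 300 nM
- compound 3 `CCCCS(=O)(=O)Nc1cc(-c2ccc3ncc(C(=O)OCC)n3c2)cnc1OC` gives 830 nM
- compound 2 `CCOC(=O)c1cnc2ccc(-c3cnc(OC)c(NS(=O)(=O)c4ccc(F)cc4)c3)cn12` is reported only as a limit, > 20000 nM

Compound 1 stands lowest of the two numbers given; the nearest is compound 3, with a 2.8-fold higher number from compound 1 to compound 3 (0.44 log units; beyond the scatter). Compound 2 sits at the limit of this assay, (the limit of > 20000 nM in this assay, at which 1 of the 3 values shown sits). All three measured steps concern the group on the sulfonyl sulfur or the fluoro on its aromatic ring: an at least 66-fold higher number from compound 1 to compound 2 (1.82 log units; beyond the scatter), a 2.8-fold higher number from compound 1 to compound 3 (0.44 log units; beyond the scatter) and an at least 24-fold lower number from compound 2 to compound 3 (1.38 log units; beyond the scatter).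

Compound 4 `COc1ncc(-c2ccc3ncc(C(=O)NCc4ccncc4)n3c2)cc1NS(=O)(=O)c1ccc(F)cc1F` differs from compound 1 elsewhere, at the carbonyl carbon of the shared core: ((pyridin-4-yl)methyl)amino in place of ethoxy on a carbonyl carbon. For the measured compounds named here, none of the measured steps touches this position, so none of them bears on the change, and the sulfonamide side that drove the large measured steps is kept unchanged from compound 1. Going by the values given here, with no step to lean on, the expected change from compound 1 to compound 4 is set within or near the scatter, a 1.2-fold lower number from compound 1 to compound 4 (0.08 log units; within the scatter), with a wide range. Compound 4 is therefore estimated at 250 nM in this assay, between 40 nM and 1600 nM.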

Compound 4, half-maximal inhibitory concentration: 980 nM
Compound 4: the middle estimate sits 3.9-fold (0.59 log units) below what was measured; the range from low to high includes it.
By their numbers in this assay, from the lowest: compound 1; then compounds 3 and 4 (each within the scatter of the next). At a limit, above all of these: compound 2.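

In this assay, the carbonyl carbon of the shared core now has a measured step of its own: the change from ethoxycarbonyl to ((pyridin-4-yl)methyl)carbamoyl gives a 3.3-fold higher number from compound 1 to compound 4 (0.51 log units; beyond the scatter) and is labelled modest, so this position accepts a larger group bearing a ring and an amide hydrogen while compound 4 keeps a number in the nanomolar range. The sulfonamide side is unchanged in this pair, so the step reads this position alone. No measured property offered here bears on this step, and its cause stays unassigned.

Which part of the new group accounts for the step stays open, as a carboxylic acid, a methylamino group or a benzylamino group on the same carbonyl carbon would be needed to separate them. Also open, on these data alone, is whether the step holds with butyl on the sulfonyl sulfur.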